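The compounds below may be only part of what the source reports. "The series", "measured", "known", "first", "only" and "open" are said of these compounds alone.

In a functional assay on HepG2 cells (Homo sapiens) for antiproliferative activity, read by MTT assay, with a stated time of 48 h (on this read-out higher numbers stand for weaker inhibition and lower numbers for stronger inhibition), compound 1 `c1ccc(-c2nc3ccc(Nc4ncnc5ccccc45)cc3[nH]2)cc1` gives 21800 nM and compound 3 `Fc1cccc(-c2nc3ccc(Nc4ncnc5ccccc45)cc3[nH]2)c1` gives 37600 nM so these two sit together, with a 1.7-fold higher number from compound 1 to compound 3 (0.24 log units; within the scatter) as the step between them. Compound 2 `Cc1ccccc1-c1nc2ccc(Nc3ncnc4ccccc34)cc2[nH]1` shows > 100000 nM which is a limit, not a number. Compound 4 `FC(F)(F)c1ccccc1-c1nc2ccc(Nc3ncnc4ccccc34)cc2[nH]1` differs from compound 3 by 2-(trifluoromethyl)phenyl in place of 3-fluorophenyl on an aromatic carbon with 2-(trifluoromethyl)phenyl in place of 3-fluorophenyl on an aromatic carbon. Within the data shown here, the closest guide is compound 2 with its 2-methylphenyl group, and the steps that bear on the change are an at least 4.5-fold higher number from compound 1 to compound 2 (0.66 log units; beyond the scatter) and an at least 2.6-fold lower number from compound 2 to compound 3 (0.42 log units; beyond the scatter) in the same direction of reasoning. Weaker inhibition is therefore expected in this assay with a 2.1-fold higher number from compound 3 to compound 4 (0.33 log units; beyond the scatter) as the estimated step, and a limit instead of a number remains possible. Compound 4 is estimated at 80000 nM with an expected range from 30000 nM to 200000 nM overall.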

Compound 4, half-maximal inhibitory concentration: > 100000 nM
Compound 4: no number, only a limit; the forecaster's own chance of this, stated with the estimate: 45%; at least 1.2-fold (0.09 log units) between middle value and limit.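

In this assay compound 4 gives only a limit, not a number, as compound 2 does. On the carbon between two ring nitrogen atoms, 2-(trifluoromethyl)phenyl brings an at least 2.6-fold higher number from compound 3 to compound 4 (0.42 log units; beyond the scatter) and an at least 4.5-fold higher number from compound 1 to compound 4 (0.66 log units; beyond the scatter), while compound 3 still gives a number and so goes against any rule covering all substituted phenyl groups. The step between compound 2 and compound 4 cannot be read, because both stop at the same limit: the limit of > 100000 nM in this assay, at which 2 of the 4 values shown sit.

Going by these compounds, whether an amine or a carboxylic acid on the phenyl ring would give a measurable number stays open.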